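Swapping the Trifluoromethylphenyl Group on the Shared Core

This account rests on a few compounds, and the source may have more. Where it says the series, first, only, none or still open, it means among the compounds named here.

This account follows a series of imidazole-based antagonists that share one core and differ in the two aryl groups attached to it. Compound 1 `FC(F)(F)c1cccc(-c2[nH]c(N3CCN(c4ncccc4C(F)(F)F)CC3)nc2-c2ccccc2)c1` carries an unsubstituted phenyl and a 3-(trifluoromethyl)phenyl; in a functional assay on CHO cells for antagonist activity at transient receptor potential cation channel subfamily V member 1 (Rattus norvegicus), read by calcium flux, at pH 5 (a lower number here means a stronger inhibitor, a higher number a weaker inhibitor), compound 1 gives 165 nM. Going by the values given here, compound 2 `Fc1cc(-c2nc(N3CCN(c4ncccc4C(F)(F)F)CC3)[nH]c2-c2ccc(C(F)(F)F)cc2)cc(F)c1F` gives 20 nM, the lowest of the three numbers measured so far. Among the compounds with values here, compound 3 `Fc1cc(F)cc(-c2nc(N3CCN(c4ncccc4C(F)(F)F)CC3)[nH]c2-c2ccc(C(F)(F)F)cc2)c1` gives 85 nM, and the single step that differs in one place, a 4.3-fold higher number from compound 2 to compound 3 (0.63 log units; beyond the scatter), shows that removing one fluoro from the trifluorophenyl ring weakens inhibition modestly.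

Compound 4 `Fc1cc(-c2nc(N3CCN(c4ncccc4C(F)(F)F)CC3)[nH]c2-c2cc(F)c(F)c(F)c2)cc(F)c1F` is not yet measured. It differs from compound 2 by 3,4,5-trifluorophenyl in place of 4-(trifluoromethyl)phenyl on an aromatic carbon. Within the data shown here, no measured pair changes this aryl group, so the step from compound 2 to compound 3 bears on it only indirectly, by showing that fluorine substitution on an aryl ring of this core can move the number beyond the scatter. The trifluoromethyl group of compound 2 is lost, and the entering group resembles the ring that compound 2 already carries on the other side of the core.

On that basis, compound 4 is expected to give a somewhat higher number, around 45 nM, within 12 nM to 160 nM, a step of a 2.3-fold higher number from compound 2 to compound 4 (0.35 log units; beyond the scatter) that is estimated rather than known.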

Compound 4, half-maximal inhibitory concentration: 32 nM
Compound 4: middle estimate off by 1.4-fold (0.15 log units), on the high side, and the stated range covers the measured number.
By their numbers in this assay, from the lowest: compounds 2 and 4 (each within the scatter of the next); then compounds 3 and 1 (each within the scatter of the next).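

In this assay, going by these compounds alone, this is the first measured change to this aryl group, and 3,4,5-trifluorophenyl in place of 4-(trifluoromethyl)phenyl gives a 1.6-fold higher number from compound 2 to compound 4 (0.20 log units; within the scatter) and so does not separate the two groups. At this aromatic carbon of the shared core, the trifluoromethyl group is therefore not needed for a number of this size, since three fluoro substituents on the ring serve equally well in this comparison. Within the data shown here, that contrasts with the only earlier step, on the other aryl group, where hydrogen in place of fluoro gives a 4.3-fold higher number from compound 2 to compound 3 (0.63 log units; beyond the scatter) and moves the number beyond the scatter. No evidence is given that would explain why these two groups cannot be told apart here.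

The compounds shown leave open whether this position accepts only groups carrying fluorine, or whether a nitrile, a methoxy group or an amine on this phenyl ring would also keep the number in this range. They also leave open whether removing one fluoro from the 3,4,5-trifluorophenyl group at this position would weaken inhibition as it does on the other aryl group.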